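Side-chain replacement on the shared core: compound 4

This account rests on a few compounds, and the source may have more. Where it says the series, first, only, none or still open, it means among the compounds named here.

Measured compounds, in a functional assay on cells for antagonist activity at C-X-C chemokine receptor type 4 (Homo sapiens), read by fluorescence and calcium flux, with stated times of 25 min and 90 s; on this read-out higher numbers stand for weaker inhibition and lower numbers for stronger inhibition:
compound 1 `c1ccc2c(c1)CN[C@@H](CN(CCCCNCC1CCSCC1)[C@H]1CCCc3cccnc31)C2` gives 69.6 nM
compound 2 `O=S1(=O)CCC(CNCCCCN(C[C@H]2Cc3ccccc3CN2)[C@H]2CCCc3cccnc32)CC1` gives 17 nM
compound 3 `CC1(C)CCC(NCCCCN(C[C@H]2Cc3ccccc3CN2)[C@H]2CCCc3cccnc32)CC1` gives 77.6 nM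

Compound 1 sits second highest of the three numbers. Its nearest neighbour is compound 3, where a 1.1-fold higher number from compound 1 to compound 3 (0.05 log units; within the scatter), a gap within the scatter. Its furthest is compound 2, where a 4.1-fold lower number from compound 1 to compound 2 (0.61 log units; beyond the scatter), a modest step beyond the scatter. Compound 3 to compound 2 shows the same picture in the other direction: a 4.6-fold higher number from compound 2 to compound 3 (0.66 log units; beyond the scatter).

Compound 4 `CC(C)(CCN)CN(C[C@H]1Cc2ccccc2CN1)[C@H]1CCCc2cccnc21` is not yet measured. Relative to compound 1 the change is a group of 6 heavy atoms (5 carbon, 1 nitrogen; no ring) in place of a group of 11 heavy atoms (9 carbon, 1 nitrogen, 1 sulfur; one six-membered non-aromatic ring with 1 hetero atom), on a saturated chain carbon bound to an amine nitrogen. Both measured steps from compound 1 alter only the group at the far end of the side chain while keeping the chain and its amine; neither removes the ring or shortens the chain as this change does, so they bear on it only loosely. They show that end-group changes move this assay between within-scatter and modest. The present change is larger in scale, and a modest weakening is expected for compound 4, with a 2.2-fold higher number from compound 1 to compound 4 (0.33 log units; beyond the scatter) as the estimated step, and wide uncertainty. Compound 4 is estimated at 150 nM, within 40 nM to 600 nM.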

Compound 4, half-maximal inhibitory concentration: > 33300 nM
Compound 4 was reported as a limit (the forecaster's own chance of this, stated with the estimate: 5%); middle value at least 220-fold (2.34 log units) away from the limit.
By their numbers in this assay, from the lowest: compound 2; then compounds 1 and 3 (each within the scatter of the next). At a limit, above all of these: compound 4.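

In this assay, the ring-free group of 6 heavy atoms in place of the group of 11 heavy atoms on the saturated chain carbon bound to an amine nitrogen gives an at least 470-fold higher number from compound 1 to compound 4 (2.67 log units; beyond the scatter), a large step and the first in the series to go far beyond a modest size. The reading for compound 4 is a limit of the assay, not a number: the limit of > 33300 nM in this assay, at which 1 of the 4 values shown sits. Among these compounds, the side-chain end had so far accepted exchange of one ring-bearing group for another, with a 1.1-fold higher number from compound 1 to compound 3 (0.05 log units; within the scatter) and a 4.1-fold lower number from compound 1 to compound 2 (0.61 log units; beyond the scatter), so this position tolerates those ring changes among compounds 1, 2 and 3 but not the ring-free group of compound 4.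

The change in compound 4 alters the ring, the chain and the amine together, so the compounds shown cannot assign the loss to any one of them. Still open, going by these compounds, is whether activity would return with a plain cyclohexyl on the shortened chain, or with a longer open chain ending in an amine and carrying no ring.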